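Trimming the Piperidine Substituent of a Potent Y1 Ligand

This account rests on a few compounds, and the source may have more. Where it says the series, first, only, none or still open, it means among the compounds named here.

Compound 2 `O=C(CCN1CCC(CCCn2c(COc3ccccc3)nc3c(OCCCN4CCCCC4)cccc32)CC1)c1ccccc1` holds the lowest number of the two measured in an in vitro assay on AV12 cells for binding affinity to Neuropeptide Y receptor type 1 (Homo sapiens) (on this read-out higher numbers stand for weaker inhibition and lower numbers for stronger inhibition), where compound 2 gives 0.112 nM; compound 1 `c1ccc(OCc2nc3c(OCCCN4CCCCC4)cccc3n2CCCC2CCN(CC3CCCCC3)CC2)cc1` gives 0.393 nM in this assay. For the measured compounds named here, the one measured step, a 3.5-fold lower number from compound 1 to compound 2 (0.55 log units; beyond the scatter), bears on the change to compound 3 `C=CCN1CCC(CCCn2c(COc3ccccc3)nc3c(OCCCN4CCCCC4)cccc32)CC1`: vinyl in place of benzoylmethyl on a saturated chain carbon bound to an amine nitrogen in a ring. Since enlarging the group at this place strengthened binding, shrinking it well below even the cyclohexyl of compound 1 is expected to weaken it, with an 8.9-fold higher number from compound 2 to compound 3 (0.95 log units; beyond the scatter). Compound 3 is therefore estimated at 1 nM, within 0.3 nM to 4 nM.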

Compound 3, inhibition constant: 1.63 nM
Compound 3: middle estimate off by 1.6-fold (0.21 log units), on the low side; the range from low to high includes it.
By their numbers in this assay, from the lowest: compound 2; then compound 1; then compound 3.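

In this assay, vinyl in place of benzoylmethyl gives a 15-fold higher number from compound 2 to compound 3 (1.16 log units; beyond the scatter), and vinyl in place of cyclohexyl gives a 4.1-fold higher number from compound 1 to compound 3 (0.62 log units; beyond the scatter). This place therefore tolerates a small group, though at a cost, and among these three compounds the number rises as the group shrinks, with none going against that order. No evidence is available on what underlies this order.

Going by these compounds, it remains open whether the carbonyl or the phenyl ring of benzoylmethyl accounts for its lead over vinyl. A phenylpropyl group, or a hydroxyl in place of that carbonyl, would bear on this question.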